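From hydroxy to ethoxy in an antiproliferative series

This account rests on a few compounds, and the source may have more. Where it says the series, first, only, none or still open, it means among the compounds named here.

In a functional assay on KB cells (Homo sapiens) for antiproliferative activity, read by sulforhodamine B assay, with a stated time of 3 days (a higher number here means that more compound is needed for the effect, a lower number that less compound is needed), compound 3 (`CCC1=C(O)c2c(oc(-c3ccc(O)cc3)cc2=O)C(CC)(CC)C1=O`) gives 20.6 uM and compound 2 (`CCC1=C(O)c2c(oc(-c3ccc(C(F)(F)F)cc3)cc2=O)C(CC)(CC)C1=O`) gives 35.7 uM. The gap between them is a 1.7-fold lower number from compound 2 to compound 3 (0.24 log units; within the scatter). Compound 1 (`CCCc1ccc(-c2cc(=O)c3c(o2)C(CC)(CC)C(=O)C(CC)=C3O)cc1`) gives > 53 uM, which is a limit and not a number.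

Compound 4 (`CCOc1ccc(-c2cc(=O)c3c(o2)C(CC)(CC)C(=O)C(CC)=C3O)cc1`) carries ethyl in place of hydrogen on an oxygen on an aromatic ring, turning 4-hydroxyphenyl into 4-ethoxyphenyl: ethyl in place of hydrogen on an oxygen on an aromatic ring. This exact change has not been measured in the series. The step that bears on it most is an at least 2.5-fold lower number from compound 1 to compound 3 (0.41 log units; beyond the scatter), with hydroxy in place of propyl. Read in reverse, it suggests that a chain in place of hydroxy raises the number in this assay. The step of an at least 1.4-fold lower number from compound 1 to compound 2 (0.17 log units; that floor lies within the scatter), with trifluoromethyl in place of propyl, adds little. Ethoxy is not propyl, so only a modest rise is expected, namely a 1.8-fold higher number from compound 3 to compound 4 (0.27 log units; within the scatter). For compound 4 the estimated value is 38 uM, with an expected range from 17 uM to 60 uM.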

Compound 4, concentration for half-maximal effect: > 52.4 uM
Compound 4: only a limit was reported (the forecaster's own chance of this, stated with the estimate: 35%); at least 1.3-fold (0.13 log units) between middle value and limit.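

With ethyl on the oxygen of the 4-hydroxyphenyl group, the series gains its first step made at this oxygen itself in this assay, and that step lies beyond the scatter (an at least 2.5-fold higher number from compound 3 to compound 4 (0.40 log units; beyond the scatter)). Against the trifluoromethyl compound the floor of the step lies within the scatter (an at least 1.4-fold higher number from compound 2 to compound 4 (0.16 log units; that floor lies within the scatter)), so no clear gap can be claimed there, and the step from the propyl compound 1 to the ethoxy compound 4 cannot be read. The value of compound 4 is a limit and not a number: (the limit of > 52.4 uM in this assay, at which 1 of the 4 values shown sits).

The compounds shown leave open how far the true value of compound 4 lies from its limit. They also leave open whether a methoxy group, a shorter chain on the same oxygen, or an amine in place of the hydroxy would keep the number near that of compound 3.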